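Lipophilicity at acidic pH: thiazole amine in place of pyridine

The source may hold more compounds than are shown below. What is called first, only, known or untested is meant among the compounds shown, and "the series" means these compounds.

Compound 1 `CC(=O)NCc1csc(NC(=O)c2cc(C(C)(C)C)nn2Cc2ccccc2)n1`: 3.3
Compound 2 `CC(C)(C)c1cc(C(=O)Nc2ccccn2)n(Cc2ccccc2)n1`: 4.5

Of the compounds shown here, two have been measured in a physicochemical assay for lipophilicity, read by HPLC, at pH 3.0; on this read-out higher numbers stand for higher lipophilicity and lower numbers for lower lipophilicity. Compound 1 `CC(=O)NCc1csc(NC(=O)c2cc(C(C)(C)C)nn2Cc2ccccc2)n1` gives 3.3 in this assay. Compound 2 `CC(C)(C)c1cc(C(=O)Nc2ccccn2)n(Cc2ccccc2)n1` gives 4.5, the higher of the two numbers, lying above compound 1 by a margin that exceeds the scatter of repeated measurements.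

The step under study leads from compound 2 to compound 3 `CNCc1csc(NC(=O)c2cc(C(C)(C)C)nn2Cc2ccccc2)n1`, which has not yet been measured in this assay. The change is 4-((methylamino)methyl)-1,3-thiazol-2-yl in place of pyridin-2-yl on an amide-type nitrogen. The group that enters carries one hydrogen-bond donor and three hydrogen-bond acceptors, where the group that leaves carries none and one.

Among the measured compounds shown here, no measured pair shows this change, so the expectation rests on the two values at hand. Compound 3 is expected to fall well below compound 2, with the step of a number 3.50 log units lower from compound 2 to compound 3 (beyond the scatter) estimated to be large and downward, far beyond the scatter. The estimate for compound 3 in this assay is 1, within a range from 0 to 2.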

Compound 3, distribution coefficient: 2.6
Beside the measured number, compound 3's estimate is 1.60 log units below it, outside the stated range (above it).
By their numbers in this assay, from the lowest: compound 3; then compound 1; then compound 2.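

In this assay, the exchange of pyridin-2-yl for 4-((methylamino)methyl)-1,3-thiazol-2-yl on the amide-type nitrogen gives a number 1.90 log units lower from compound 2 to compound 3 (beyond the scatter) and counts as a large step, so this position clearly responds to the change. The result also supplies the first comparison within the thiazole-bearing pair: methyl in place of acetyl on the amine nitrogen gives a number 0.70 log units lower from compound 1 to compound 3 (beyond the scatter) and counts as a modest step, which leaves compound 3 with the lowest of the three numbers. No accompanying data bear on what lies behind either step.

Among the compounds shown here, the single exchange from compound 2 replaces the ring and adds the side chain together, and an unsubstituted 1,3-thiazol-2-yl would be needed to separate the share of each in the step. As far as these compounds go, it also remains open how a primary amine, a dimethylamino group or a hydroxyl in place of the methylamino group would read, and whether the order of these three compounds would hold at another pH.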